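The source may hold more compounds than are shown below. What is called first, only, known or untested is meant among the compounds shown, and "the series" means these compounds.

Measured compounds:
Compound 1 `CC[C@@H](c1ccc(C(=O)O)c(Oc2cccc(Cl)c2)c1F)N1CCC[C@H](n2cc(C)c(=O)[nH]c2=O)C1`: in an ADME assay on the whole organism (strain Wistar) for pharmacokinetics, with Rattus norvegicus as the target, given by the intravenous route (a lower number here means slower removal, a higher number faster removal of the compound), compound 1 gives "not determined" (no result reported).
Compound 2 `CC[C@H](c1ccc(C(=O)O)c(Oc2cccc(Cl)c2)c1F)N1CCC[C@H](n2cc(C)c(=O)[nH]c2=O)C1`: in this assay compound 2 gives 119 mL/min/kg.

Among the measured compounds shown here, compound 2 is the only member of the series with a number in this assay; compound 1 carries no result there, so the fact that compounds 1 and 2 differ only in the configuration as drawn cannot be turned into a measured step, and no step between measured compounds is available. The value of compound 2 is therefore the only anchor.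

Compound 3 `CCC[C@H](c1ccc(C(=O)O)c(Oc2cccc(Cl)c2)c1F)N1CCC[C@H](n2cc(C)c(=O)[nH]c2=O)C1` extends the chain of compound 2: methyl in place of hydrogen on a saturated chain carbon, three bonds along the chain from an amine nitrogen in a ring and an aromatic carbon. For the measured compounds named here, with no measured step to lean on, the expectation for this assay is a change no larger than the usual scatter in either direction. Compound 3 is estimated at 120 mL/min/kg, with a likely range from 60 mL/min/kg to 240 mL/min/kg. The step this estimate implies is a 1.0-fold higher number from compound 2 to compound 3 (0.00 log units; within the scatter), which is expected to stay within the scatter.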

Compound 3, clearance: 64 mL/min/kg
Estimate against measurement, compound 3: 1.9-fold (0.27 log units) above; low and high end bracket the measured number.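

Among the compounds shown here, with the change from ethyl to propyl, this position gives the first measured step in this assay: a 1.9-fold lower number from compound 2 to compound 3 (0.27 log units; within the scatter). A single methyl in place of hydrogen at this saturated chain carbon therefore yields a step that cannot be separated from repeat-measurement noise, so this pair gives no basis for ranking the two chains in this assay. The information available gives no account of what lies behind this step.

One pair cannot show whether a longer chain at this position, such as butyl, or a branched or hydroxyl-bearing chain, would produce a step beyond the scatter. From the compounds shown here alone, the contribution of the configuration as drawn at this carbon to the read-out also remains open.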